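Adding a Third Methoxy to a Trimethoxybenzoyl Enone Ester

The source may hold more compounds than are shown below. What is called first, only, known or untested is meant among the compounds shown, and "the series" means these compounds.

Compound 3 `CCOC(=O)/C(=C/c1ccc(OC)c(OC)c1)C(=O)c1cc(OC)c(OC)c(OC)c1` is one of three measured members of a small series of aryl enone esters. In an ADME assay on K562 cells (Homo sapiens) for cytotoxicity, read by MTT assay, with a stated time of 5 days (a higher number here means a weaker inhibitor, a lower number a stronger inhibitor), compound 3 gives > 10000 nM, which is a limit of the assay rather than a number. Compound 1 `CCOC(=O)/C(=C/c1ccc(OC)cc1)C(=O)c1cc(OC)c(OC)c(OC)c1` sits at the same limit, giving > 10000 nM in this assay. Compound 2 `CCOC(=O)/C(=C/c1ccc(OC)c(O[Si](C)(C)C(C)(C)C)c1)C(=O)c1cc(OC)c(OC)c(OC)c1` gives 4290 nM in this assay, and the steps of an at least 2.3-fold lower number from compound 1 to compound 2 (0.36 log units; beyond the scatter) and an at least 2.3-fold higher number from compound 2 to compound 3 (0.36 log units; beyond the scatter) are the only readable ones in the set. Among the compounds with values here, the step that the two limits leave unreadable from compound 1 to compound 3 is the one that matches the change under study most closely, and it stays unreadable because the limit of > 10000 nM in this assay, at which 2 of the 3 values shown sit, holds both of its compounds.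

Compound 4 `CCOC(=O)/C(=C/c1ccc(OC)c(OC)c1OC)C(=O)c1cc(OC)c(OC)c(OC)c1` differs from compound 3 by methoxy in place of hydrogen on an aromatic carbon. No readable step speaks to this change, so no shift beyond the scatter is expected, and compound 4 is most likely to remain at the limit. Compound 4 is expected at 15000 nM, with a range from 6000 nM to 40000 nM. This estimate means an expected step that the limit leaves unreadable from compound 3 to compound 4.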

Compound 4, half-maximal inhibitory concentration: > 10000 nM
Compound 4: a limit, no number (the forecaster's own chance of this, stated with the estimate: 75%); the middle value is on the limit's open side.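

No step can be read from compound 3 to compound 4, since both compounds sit at the same limit: the limit of > 10000 nM in this assay, at which 3 of the 4 values shown sit. The compounds shown leave open whether methoxy in place of hydrogen on this aromatic carbon changes the result in this assay at all.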